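A few compounds are considered here, and "the series" means these few. Any claim that something is new, unique, unknown or untested is made for them only; others in the source may bear on it.

Measured so far:
compound 1, `CCC(C)C(C(=O)Nc1ccc(C(C)=O)cc1)N(C(=O)c1ccccc1)S(=O)(=O)c1ccc(C)cc1`, 18.6%
compound 2, `CC(=O)c1ccc(NC(=O)CN(C(=O)c2ccccc2)S(=O)(=O)c2ccccc2)cc1`, 40.5%

Within the data shown here, in a functional assay for inhibition, read by spectrophotometry, with a stated time of 20 min, tested at 1 mg/mL (a lower number here means a weaker effect, a higher number a stronger effect of the compound at the concentration tested), compound 2 gives 40.5%, the higher of the two numbers known. Compound 1 gives 18.6% in this assay, a number lower than that of compound 2 by a margin beyond the usual scatter. Among the measured compounds shown here, no pair of measured compounds differs in one place only, so no step between measured compounds can be stated; compound 1 and compound 2 differ in more than one place, and their two values show only that the sec-butyl-bearing compound 1 sits lower.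

Compound 3, `CCC(C)C(C(=O)Nc1ccc(C(C)=O)cc1)N(C(=O)c1ccccc1)S(=O)(=O)c1ccccc1`, has not been measured. It differs from compound 2 by sec-butyl in place of hydrogen on a saturated chain carbon bound to an amide-type nitrogen and a carbonyl carbon. Compound 3 thus carries the same sec-butyl as compound 1 while matching compound 2 elsewhere. Resting on the lower value of compound 1, a decrease beyond the scatter is expected from compound 2 to compound 3 in this assay, roughly a number 15.5 percentage points lower from compound 2 to compound 3 (beyond the scatter). Compound 3 is estimated at 25%, with an expected range from 12% to 40%.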

Compound 3, a percentage reported as inhibition, at one concentration (the size of the read-out at that concentration, not a potency): 9.71%
Estimate against measurement, compound 3: 15.3 percentage points above, outside the stated range (below it).
By their numbers in this assay, from the lowest: compounds 3 and 1 (each within the scatter of the next); then compound 2.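

Working notes on the series. In this assay, the change of sec-butyl in place of hydrogen on a saturated chain carbon bound to an amide-type nitrogen and a carbonyl carbon now has a reading in one place only: a number 30.8 percentage points lower from compound 2 to compound 3 (beyond the scatter) is the step at this position, and it is a large one. The other single change, hydrogen in place of methyl on an aromatic carbon, gives a number 8.9 percentage points lower from compound 1 to compound 3 (within the scatter) and so does not separate the sec-butyl compounds in this read-out. The earlier pair differed in more than one place and could not assign its gap to either change, whereas these two steps place the large change at the chain carbon and leave none beyond the scatter at the aromatic carbon.

The compounds shown leave open how a methyl, an isopropyl or a straight butyl chain on the same chain carbon would read, and whether a carboxylic acid or an amine there would read differently from sec-butyl. No measurement among those given bears on the reason for the step at the chain carbon.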